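The source may report more compounds than this note shows. Statements on the series, on what has been measured and on what is new or still open speak of the compounds shown alone.

Compound 1: `CC(=O)Nc1cc(Nc2cc(NC3CC3)n3ncc(C#N)c3n2)ccc1N1CCC[C@@H](N)C1` — in this assay a limit of the assay, < 1 uL/min.
Compound 2: `CC(=O)Nc1cc(Nc2cc(NC3CC3)n3ncc(C#N)c3n2)ccc1NCCCO` — 17 uL/min.
Compound 3: `CC(=O)Nc1cc(Nc2cc(NC3CC3)n3ncc(C#N)c3n2)ccc1N1CCC[C@H](N)C1` — a limit of the assay, < 1 uL/min.

Within the data shown here, in an ADME assay on cells (Hepatocyte, Rattus norvegicus) for metabolic stability (a higher number here means faster removal of the compound, a lower number slower removal), compound 2 gives the only actual number of the three; compound 1 and compound 3 each sit at a limit of the assay. The next compound, compound 4 `CCN(CCN)c1ccc(Nc2cc(NC3CC3)n3ncc(C#N)c3n2)cc1NC(C)=O`, is related to compound 2 by a single change: a group of 6 heavy atoms (4 carbon, 2 nitrogen; no ring) in place of a group of 5 heavy atoms (3 carbon, 1 nitrogen, 1 oxygen; no ring), on an aromatic carbon.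

Among the measured compounds shown here, two measured steps bear on this. Both an at least 17-fold higher number from compound 1 to compound 2 (1.23 log units; beyond the scatter) and an at least 17-fold lower number from compound 2 to compound 3 (1.23 log units; beyond the scatter) swap the (3-hydroxypropyl)amino group for 3-aminopiperidin-1-yl, and each lowers the number strongly. The step that the two limits leave unreadable from compound 1 to compound 3 cannot be sized because of the limit of < 1 uL/min in this assay, at which 2 of the 3 values shown sit. The group entering in compound 4 also carries 2 nitrogen atoms and no oxygen, so a lower number than that of compound 2 is expected, though the entering group has no ring and the size of the drop is uncertain.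

Compound 4 is therefore expected to fall near 3 uL/min, within a range from 0.8 uL/min to 12 uL/min. This estimate amounts to an expected step of a 5.7-fold lower number from compound 2 to compound 4 (0.75 log units; beyond the scatter).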

Compound 4, intrinsic clearance in a liver preparation (reported as CLH), per the amount of preparation that the assay uses: 2 uL/min
For compound 4 the middle estimate is 1.5-fold (0.18 log units) above the measured one, and the stated range covers the measured number.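

The earlier compounds shown here showed a drop only with 3-aminopiperidin-1-yl on this aromatic carbon, ortho to an acetamido group, but compound 4 shows in this assay that a group with no ring can also lower the number, with an 8.5-fold lower number from compound 2 to compound 4 (0.93 log units; beyond the scatter). Measured against the two ring compounds, the open-chain group gives only an at least 2.0-fold higher number from compound 3 to compound 4 (0.30 log units; that floor lies within the scatter) and an at least 2.0-fold higher number from compound 1 to compound 4 (0.30 log units; that floor lies within the scatter), and both of these floors lie within the scatter. Compound 1 and compound 3 each stand at a limit of the assay, so the true distance from either one to compound 4 stays unknown: the limit of < 1 uL/min in this assay, at which 2 of the 4 values shown sit.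

The compounds shown do not separate the part played by the chain's end amine from that of the ethyl group on the nitrogen attached to the aromatic ring. From the compounds shown here alone, it also remains open how this assay would respond to a longer chain ending in an amine, or to a chain ending in a carboxylic acid.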